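The compounds below may be only part of what the source reports. "The series", "measured", "known", "first", "only" and "open" are said of these compounds alone.

Measured so far:
- compound 1, `CCc1c(SC)nc2nc(C(=O)c3ccccc3)cn2c1C`: 2 mg/kg
- compound 2, `CCCCc1c(OC)nc2nc(C(=O)c3ccccc3)cn2c1CC`: 10 mg/kg
- compound 3, `CCc1c(OC)nc2nc(C(=O)c3ccccc3)cn2c1C`: 2 mg/kg

All three were tested in a functional assay on the whole organism with Rattus norvegicus as the target; on this read-out lower numbers stand for an effect already at smaller amounts and higher numbers for an effect only at larger amounts of compound. Compound 1 gives 2 mg/kg, and compound 3 gives 2 mg/kg; the two stand level, and together they hold the lowest numbers of the three. Among the measured compounds shown here, the only single-point step among them, no change at the digits printed from compound 1 to compound 3 (within the scatter), shows that swapping methylsulfanyl for methoxy on the core leaves the read-out unchanged. Compound 2, which carries longer chains on the shared core, gives 10 mg/kg, a clearly higher number than compound 1 shows, though it differs from compound 1 in more than one place.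

Compound 4, `CSc1cc(C)n2cc(C(=O)c3ccccc3)nc2n1`, has not yet been measured. It differs from compound 1 in one respect:
hydrogen in place of ethyl on an aromatic carbon

For the measured compounds named here, no measured step removes an alkyl chain, so the only guide is that compound 2 with its longer chains reads 10 mg/kg while compound 1 reads 2 mg/kg. Chain size therefore seems to matter, but the direction of shortening is untested. For compound 4 in this assay a small shift is expected, a 1.5-fold higher number from compound 1 to compound 4 (0.18 log units; within the scatter), and the estimate for compound 4 is 3 mg/kg with a range from 1 mg/kg to 10 mg/kg.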

Compound 4, minimum effective dose: 5 mg/kg
The estimate for compound 4 lay 1.7-fold (0.22 log units) below the measured number, within the range that was stated.
By their numbers in this assay, from the lowest: compounds 1 and 3 (each within the scatter of the next); then compounds 4 and 2 (each within the scatter of the next).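

In this assay the change to hydrogen in place of ethyl on this aromatic carbon gives a 2.5-fold higher number from compound 1 to compound 4 (0.40 log units; beyond the scatter) and so lies beyond the scatter. This is the first single-place change among these compounds that moves the number, whereas the earlier swap of methylsulfanyl for methoxy did not, which shows that the read-out responds to what sits at this position. No measurement shown here speaks to the reason for this shift.

On these data alone, what a propyl chain, a chlorine atom or an amine would do at this carbon remains open, as only ethyl and hydrogen can be compared here in a single-place step. Also open, as far as these compounds go, is whether methoxy in place of methylsulfanyl would still leave the number unchanged on a core that carries hydrogen instead of ethyl.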